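Hexyl to Phenyl on the Aminopyridine Amide Core

This account rests on a few compounds, and the source may have more. Where it says the series, first, only, none or still open, it means among the compounds named here.

Compound 1, `CCCOc1ccc(C(=O)Nc2cccc(Br)n2)cc1`, carries a bromo on an aromatic carbon of the shared core. In an in vitro assay on HEK-tsA201 cells for antagonist activity at Neuronal acetylcholine receptor; alpha3/beta4 (Homo sapiens), read by fluorescence and calcium flux (a higher number here means a weaker inhibitor, a lower number a stronger inhibitor), compound 1 gives only a limit, > 100000 nM. Compound 2, `CCCCCCNc1cccc(NC(=O)c2ccc(OCCC)cc2)n1`, has hexylamino in place of that bromo. In this assay compound 2 likewise gives only a limit, > 100000 nM. The step between them, a step that the two limits leave unreadable from compound 1 to compound 2, cannot be read, as both of its ends are limits. What the measurements so far show is the limit of > 100000 nM in this assay, at which 2 of the 2 values shown sit, and compound 2 stands at that limit with no number of its own.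

Compound 3, `CCCOc1ccc(C(=O)Nc2cccc(Nc3ccccc3)n2)cc1`, differs from compound 2 by phenyl in place of hexyl on a nitrogen on an aromatic ring. Among the compounds with values here, no measured step mirrors this change, and the single measured step is unreadable, so the only guide is that both measured compounds sit at the limit. Compound 3 is therefore expected to sit near the same limit, with an estimated value of 150000 nM and a range from 40000 nM to 600000 nM. The expected step is a step that the limit leaves unreadable from compound 2 to compound 3, which means no change beyond the scatter.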

Compound 3, half-maximal inhibitory concentration: > 100000 nM
Compound 3 was reported as a limit (the forecaster's own chance of this, stated with the estimate: 80%); the middle value lies beyond the limit too.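

In this assay compound 3 gives > 100000 nM as a limit, just as compound 1 and compound 2 do, so its steps from compound 1 and from compound 2 cannot be read. The compounds shown leave open how strongly each one inhibits, and whether any group at this place on the shared core gives a readable number.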